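The source may hold more compounds than are shown below. What is called first, only, known or untested is meant among the compounds shown, and "the series" means these compounds.

Compound 3 `COc1cc2c(Oc3ccc(NC(=O)c4nn(-c5ccc(Cl)cc5)c(=O)cc4C)cc3F)ccnc2cc1OCCCN1CCCC1` gives 260 nM in a functional assay on HT-29 cells (Homo sapiens) for inhibition, read by MTT assay, with a stated time of 72 h; a higher number here means a weaker inhibitor, a lower number a stronger inhibitor. Compound 2 `COc1cc2c(Oc3ccc(NC(=O)c4nn(-c5cccc(F)c5)c(=O)cc4C)cc3F)ccnc2cc1OCCCN1CCN(C)CC1` gives 250 nM, a number within the scatter of compound 3, while compound 1 `COc1cc2c(Oc3ccc(NC(=O)c4nn(-c5ccccc5C)c(=O)cc4C)cc3F)ccnc2cc1OCCCN1CCN(C)CC1` gives 3790 nM, so compound 3 stands far below compound 1 and alongside compound 2. Going by the values given here, the one measured step, a 15-fold lower number from compound 1 to compound 2 (1.18 log units; beyond the scatter), concerns the aryl on the aromatic nitrogen and leaves the chain end untouched. Compound 4 `COc1cc2c(Oc3ccc(NC(=O)c4nn(-c5ccc(Cl)cc5)c(=O)cc4C)cc3F)ccnc2cc1OCCCN1CCN(C)CC1` differs from compound 3 only at that chain end: 4-methylpiperazin-1-yl in place of pyrrolidin-1-yl on a saturated chain carbon, three bonds along the chain from an oxygen on an aromatic ring. Among the compounds with values here, no measured pair shows this exchange, so nothing here argues for movement either way. The expectation is a step within the scatter, no change at the digits printed from compound 3 to compound 4 (within the scatter). Compound 4 is therefore estimated at 260 nM, between 100 nM and 700 nM.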

Compound 4, half-maximal inhibitory concentration: 320 nM
The estimate for compound 4 lay 1.2-fold (0.09 log units) below the measured number; low and high end bracket the measured number.
By their numbers in this assay, from the lowest: compounds 2, 3 and 4 (each within the scatter of the next); then compound 1.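

In this assay, the chain-end exchange gives a 1.2-fold higher number from compound 3 to compound 4 (0.09 log units; within the scatter) with the 4-chlorophenyl group held constant, so this position tolerates 4-methylpiperazin-1-yl and pyrrolidin-1-yl alike in this pair. With 4-methylpiperazin-1-yl held constant, 4-chlorophenyl gives a 1.3-fold higher number from compound 2 to compound 4 (0.11 log units; within the scatter) against 3-fluorophenyl and a 12-fold lower number from compound 1 to compound 4 (1.07 log units; beyond the scatter) against 2-methylphenyl, so the one large change among these pairs lies on the aromatic nitrogen, not at the chain end. Nothing available explains these results. On these data alone, whether morpholin-4-yl, a dimethylamino group or a longer chain would fit equally well at this position remains open.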